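The source may hold more compounds than are shown below. What is called first, only, known or untested is meant among the compounds shown, and "the series" means these compounds.

In an ADME assay on the whole organism (Rattus norvegicus) for metabolic stability, at a dose of 1 mg/kg by the intravenous route (on this read-out lower numbers stand for a shorter-lived compound and higher numbers for a longer-lived compound), compound 1 (`Cc1ccc([C@H](C)NC(=O)Cn2nnc3ccccc3c2=O)cc1`) gives 0.4 h and compound 2 (`COc1cccc2nnn(CC(=O)N[C@@H](C)c3ccc(C)cc3)c(=O)c12`) gives 0.5 h within the scatter of each other. For the measured compounds named here, compound 3 (`COc1ccc2nnn(CC(=O)N[C@@H](C)c3ccc(C)cc3)c(=O)c2c1`) differs from compound 1 by methoxy in place of hydrogen on an aromatic carbon as methoxy in place of hydrogen on an aromatic carbon, on a different carbon from the one in compound 2. Going by the values given here, the only measured step of this kind is a 1.3-fold higher number from compound 1 to compound 2 (0.10 log units; within the scatter) and it lies within the scatter, so no step beyond the scatter is expected in this assay here. For compound 3 the estimated half-life is 0.5 h with an expected range from 0.25 h to 1 h on repeated measurement. The expected step is a 1.3-fold higher number from compound 1 to compound 3 (0.10 log units; within the scatter) on this estimate.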

Compound 3, half-life: 0.3 h
Estimate against measurement, compound 3: 1.7-fold (0.22 log units) above, within the range that was stated.
By their numbers in this assay, from the lowest: compounds 3, 1 and 2 (each within the scatter of the next).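

In this assay, with a 1.3-fold lower number from compound 1 to compound 3 (0.12 log units; within the scatter) for methoxy on this aromatic carbon, meta to a fused ring and para to a fused ring, a second aromatic carbon of the core now takes this change without a step beyond the scatter. The half-life of compound 3 therefore cannot be separated from that of compound 1 on this read-out. No measurement shown gives a reason for this. From the compounds shown here alone, whether an amine, a carboxylic acid or a longer alkoxy chain on this carbon would give a step beyond the scatter stays open.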